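Furan-2-yl for phenyl on the shared core

A few compounds are considered here, and "the series" means these few. Any claim that something is new, unique, unknown or untested is made for them only; others in the source may bear on it.

Two compounds of this series carry numbers in a functional assay on SK-MEL-2 cells (Homo sapiens) for antiproliferative activity; a higher number here means that more compound is needed for the effect, a lower number that less compound is needed. Compound 1 `c1ccc(-c2cc(-c3cccs3)cc(-c3ccco3)n2)cc1` gives 118000 nM. Compound 2 `c1coc(-c2ccnc(-c3ccco3)c2)c1` gives 118000 nM. Compound 1 therefore stands level with compound 2 at the digits shown; the two values lie within the scatter of each other, and neither compound can be called the more active one.

Compound 3 `c1coc(-c2cc(-c3cccs3)cc(-c3ccco3)n2)c1` is not yet measured. It differs from compound 1 in a single place: furan-2-yl in place of phenyl on an aromatic carbon, in words furan-2-yl in place of phenyl on an aromatic carbon, next to the ring nitrogen, meta to a furan-2-yl group and meta to a thiophen-2-yl group. Going by the values given here, no step between two measured compounds covers this exchange. What is known is that compound 2, which carries furan-2-yl groups and no phenyl, sits at the same number as compound 1 in this assay, which gives no ground to expect a shift in either direction. Expected is a step of no change at the digits printed from compound 1 to compound 3 (within the scatter), that is none beyond the scatter. Compound 3 is expected near 118000 nM, with a range from 50000 nM to 250000 nM.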

Compound 3, half-maximal effective concentration: 118000 nM
Compound 3: the middle estimate sits on the measured number at the digits printed, within the range that was stated.
By their numbers in this assay, from the lowest: compounds 1, 2 and 3 (each within the scatter of the next).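

Going by these compounds alone, with no change at the digits printed from compound 1 to compound 3 (within the scatter) for furan-2-yl in place of phenyl next to the ring nitrogen, this is the first direct reading of this position in this assay. The exchange replaces a six-membered aromatic ring of carbon only with a five-membered aromatic ring with 1 hetero atom and brings in 1 hydrogen-bond acceptor, yet compound 3 at 118000 nM cannot be told apart from compound 1, so phenyl and furan-2-yl are interchangeable here within the scatter of this read-out. No measured property in the series bears on this flat step, and the data offer no explanation for it.

From the compounds shown here alone, both groups compared at this position are aromatic rings, so whether an amine, a carboxylic acid or a longer alkyl chain there would move the number remains open. The thiophen-2-yl group is the same in compound 1 and compound 3, and this pair says nothing about what exchanging that group would do.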